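The compounds below may be only part of what the source reports. "The series", "measured", "known", "first", "only" and "open" are said of these compounds alone.

Compound 1 `COC[C@H](C)[C@H](C)C(c1ccc(O)c(OC)c1)c1ccc(O)c(OC)c1` gives 82000 nM in a functional assay on HL-60 cells (Homo sapiens) for cytotoxicity, read by WST assay, with a stated time of 48 h; on this read-out higher numbers stand for weaker inhibition and lower numbers for stronger inhibition.
Compound 2 `COc1cc(C(c2ccc(O)c(OC)c2)[C@@H](CO)C(C)C)ccc1O` reaches only the assay limit, > 100000 nM.
Compound 3 `COc1ccc(C(c2ccc(OC)c(OC)c2)[C@@H](C)[C@@H](C)CO)cc1OC` likewise reaches only the assay limit, > 100000 nM.

Compound 2 thus stands at a limit of this assay, and no number is known for it; only an upper bound on its cytotoxic strength can be read. Compound 4 `CCCCC[C@H](C(C)C)C(c1ccc(O)c(OC)c1)c1ccc(O)c(OC)c1` differs from it by 1-isopropylhexyl in place of 1-(hydroxymethyl)-2-methylpropyl on a saturated chain carbon bound to two aromatic carbons. Among the compounds with values here, the single measured step at this place is an at least 1.2-fold higher number from compound 1 to compound 2 (0.08 log units; that floor lies within the scatter), which stays within the scatter. Given (the limit of > 100000 nM in this assay, at which 2 of the 3 values shown sit), the anchor for the new step is weak. The step of an at least 1.6-fold lower number from compound 2 to compound 4 (0.22 log units; that floor lies within the scatter) is therefore expected to be modest, with a real chance that only a limit is reported again. Compound 4 is estimated at 60000 nM, expected between 20000 nM and 150000 nM.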

Compound 4, half-maximal inhibitory concentration: 9600 nM
Compound 4: the middle estimate sits 6.3-fold (0.80 log units) above what was measured; measured number below the stated range.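

In this assay the place on a saturated chain carbon bound to two aromatic carbons now shows a clear effect, which the earlier step within the scatter did not: 1-isopropylhexyl gives an at least 10-fold lower number from compound 2 to compound 4 (1.01 log units; beyond the scatter) and also an 8.5-fold lower number from compound 1 to compound 4 (0.93 log units; beyond the scatter). Compound 2 gives only a limit, > 100000 nM, so the first of these steps is a floor: the limit of > 100000 nM in this assay, at which 2 of the 4 values shown sit. Both oxygen-bearing groups thus fall behind the all-carbon group.

The compounds shown do not separate the larger chain from the loss of oxygen. As far as these compounds go, how an amine or a longer chain would read at this place stays open.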